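Replacing oxan-2-yl with ethyl in compound 3

The source may hold more compounds than are shown below. What is called first, only, known or untested is meant among the compounds shown, and "the series" means these compounds.

In an ADME assay on a cell-free system (plasma, Homo sapiens) for metabolic stability, read by LC-MS (a higher number here means that the compound lasts longer, a lower number that the compound disappears faster), compound 3 `NCc1ccc(C(=O)Nc2ccncc2F)cc1-c1cccc(C(=O)OCC2CCCCO2)c1` gives 0.117 h, level with compound 1 `NCc1ccc(C(=O)Nc2ccncc2F)cc1-c1cccc(C(=O)Oc2ccccc2)c1` at 0.117 h, and the two share the lowest number of the three measured. Compound 2 `NCc1ccc(C(=O)Nc2ccncc2F)cc1-c1cccc(C(=O)OCC2CC2)c1` stands at 0.3 h.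

Compound 4 `CCCOC(=O)c1cccc(-c2cc(C(=O)Nc3ccncc3F)ccc2CN)c1` carries ethyl in place of oxan-2-yl on a saturated chain carbon bound to an oxygen next to a carbonyl group. The closest guide is a 2.6-fold lower number from compound 2 to compound 3 (0.41 log units; beyond the scatter), where oxan-2-yl replaced cyclopropyl. Also relevant are a 2.6-fold higher number from compound 1 to compound 2 (0.41 log units; beyond the scatter) and no change at the digits printed from compound 1 to compound 3 (within the scatter). Read in reverse, the first suggests that losing oxan-2-yl may recover a modest rise. The expected change is a 2.4-fold higher number from compound 3 to compound 4 (0.38 log units; beyond the scatter). The estimate for compound 4 is 0.28 h, with an expected range of 0.13 h to 0.6 h.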

Compound 4, half-life: 0.317 h
The estimate for compound 4 lay 1.1-fold (0.05 log units) below the measured number; the measured number falls inside the stated range.
By their numbers in this assay, from the lowest: compounds 1 and 3 (each within the scatter of the next); then compounds 2 and 4 (each within the scatter of the next).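

In this assay, ethyl in place of oxan-2-yl on this saturated chain carbon gives a 2.7-fold higher number from compound 3 to compound 4 (0.43 log units; beyond the scatter), so the low number of compound 3 does not carry over once that ring is gone. Ethyl in place of cyclopropyl gives a 1.1-fold higher number from compound 2 to compound 4 (0.02 log units; within the scatter), so the open chain and the small ring read alike at this place. Propyl in place of phenyl on an oxygen next to a carbonyl group gives a 2.7-fold higher number from compound 1 to compound 4 (0.43 log units; beyond the scatter).

Nothing at hand explains these steps. Going by these compounds, whether a longer chain, such as butyl, or an amine on this chain would keep the number at this level stays open.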